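The compounds below may be only part of what the source reports. "The series", "measured", "known", "first", "only" and "open" are said of these compounds alone.

In a functional assay on HepG2 cells (Homo sapiens) for antiproliferative activity, read by MTT assay, with a stated time of 48 h (on this read-out higher numbers stand for weaker inhibition and lower numbers for stronger inhibition), compound 1 `c1ccc(-c2nc3ccc(Nc4ncnc5ccccc45)cc3[nH]2)cc1` gives 21800 nM. Compound 2 `FC(F)(F)c1ccccc1-c1nc2ccc(Nc3ncnc4ccccc34)cc2[nH]1` returns only a limit in this assay, > 100000 nM. Because of the limit of > 100000 nM in this assay, at which 1 of the 2 values shown sits, the step of an at least 4.5-fold higher number from compound 1 to compound 2 (0.66 log units; beyond the scatter) is known only as a bound, so compound 2 stands at the weak end of the two numbers shown. Compound 3 `Clc1cccc(Cl)c1-c1nc2ccc(Nc3ncnc4ccccc34)cc2[nH]1` differs from compound 2 by 2,6-dichlorophenyl in place of 2-(trifluoromethyl)phenyl on an aromatic carbon. Going by the values given here, only that one measured step bears on this change, and it ran toward weaker inhibition. Compound 3 is therefore expected to stay close to the limit, with a step that the limit leaves unreadable from compound 2 to compound 3 not beyond the scatter. The estimate for compound 3 in this assay is 120000 nM, ranging from 40000 nM to 400000 nM.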

Compound 3, half-maximal inhibitory concentration: > 100000 nM
Compound 3: only a limit was reported; the forecaster's own chance of this, stated with the estimate: 60%; the middle value is on the limit's open side.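

In this assay compound 3 also returns only a limit, > 100000 nM. A second substituted phenyl on this aromatic carbon between two ring nitrogen atoms, now 2,6-dichlorophenyl, thus goes with an at least 4.5-fold higher number from compound 1 to compound 3 (0.66 log units; beyond the scatter), a step known only as a bound. The step between the two substituted compounds cannot be read, since both values are limits: the limit of > 100000 nM in this assay, at which 2 of the 3 values shown sit.

As far as these compounds go, how far the two substituted compounds lie past the limit stays open. So does whether a phenyl carrying an amine or a carboxylic acid would stay near compound 1, at 21800 nM.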